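Cyclopropyl for trifluoromethyl on the pyrazole of compound 3

The source may hold more compounds than are shown below. What is called first, only, known or untested is meant among the compounds shown, and "the series" means these compounds.

Three compounds share a core in which a dimethylamide-bearing piperidine is attached to a pyridine carrying an aromatic substituent. Compound 1 `CN(C)C(=O)C1CCN(c2cnccc2-c2ccccn2)CC1` gives 68 nM in an assay on HEK293F cells for inhibition of cholesterol 24-hydroxylase (Homo sapiens), read by trypan blue exclusion, with stated times of 15 min and 5 h; on this read-out higher numbers stand for weaker inhibition and lower numbers for stronger inhibition. Compound 2 `Cc1ccn(-c2ccncc2N2CCC(C(=O)N(C)C)CC2)n1` gives 1100 nM in this assay, and the step of a 16-fold higher number from compound 1 to compound 2 (1.21 log units; beyond the scatter) shows how strongly that aromatic group matters. Compound 3 `CN(C)C(=O)C1CCN(c2cnccc2-n2cc(C(F)(F)F)cn2)CC1` gives 65 nM in this assay, the lowest of the three numbers, though its distance from compound 1 lies within the scatter, so no order between them can be claimed.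

Compound 4 `CN(C)C(=O)C1CCN(c2cnccc2-n2cc(C3CC3)cn2)CC1` differs from compound 3 in one place: cyclopropyl in place of trifluoromethyl on an aromatic carbon. Within the data shown here, no measured step concerns a change of the substituent on the five-membered ring; the only step known swaps the whole aromatic group. The expected step of a 1.4-fold higher number from compound 3 to compound 4 (0.14 log units; within the scatter) is therefore none beyond the scatter. Compound 4 is estimated at 90 nM in this assay, with a range from 35 nM to 250 nM.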

Compound 4, half-maximal inhibitory concentration in the cholesterol 24-hydroxylase assay: 12 nM
Compound 4: the middle estimate sits 7.5-fold (0.88 log units) above what was measured; measured number below the stated range.
By their numbers in the cholesterol 24-hydroxylase assay, from the lowest: compound 4; then compounds 3 and 1 (each within the scatter of the next); then compound 2.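

Among these compounds, in the cholesterol 24-hydroxylase assay compound 3 gives 65 nM and compound 4 gives 12 nM, so the exchange on this aromatic carbon of the five-membered ring gives a clear step on its own (a 5.4-fold lower number from compound 3 to compound 4 (0.73 log units; beyond the scatter)), whereas the earlier compounds showed only swaps of the whole aromatic group. The 4-cyclopropyl-1H-pyrazol-1-yl group also separates from both other aromatic groups (a 5.7-fold lower number from compound 1 to compound 4 (0.75 log units; beyond the scatter); a 92-fold lower number from compound 2 to compound 4 (1.96 log units; beyond the scatter)), leaving compound 4 with the lowest number of the four. In a physicochemical assay for lipophilicity, at pH 7.4 (a lower number here means a more polar compound, a higher number a more lipophilic compound), compound 3 gives 2.1 and compound 4 gives 2.1; the same exchange shows no change at the digits printed from compound 3 to compound 4 (within the scatter), so the stronger inhibition comes without any movement on that read-out.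

Nothing in the available material explains the size of this step. Going by these compounds, whether an amine or a longer alkyl chain on this aromatic carbon would keep the number at the level of compound 4 remains open.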